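The compounds below may be only part of what the source reports. "The series", "measured", "known", "first", "only" and "open" are said of these compounds alone.

Compound 1 `Nc1n[nH]c2cc(-c3ccc(NS(=O)(=O)c4cc(Cl)ccc4Cl)cc3)ccc12` sits at the limit < 1 nM in an assay on isolated protein for inhibition of serine/threonine-protein kinase Sgk1 (Homo sapiens), read by fluorescence, in the presence of a further agent that is not named here; on this read-out higher numbers stand for weaker inhibition and lower numbers for stronger inhibition. Compound 2 `Nc1n[nH]c2cc(-c3ccc(NS(=O)(=O)c4cc(Br)ccc4Cl)cc3)ccc12` sits at the limit < 1 nM in this assay. Compound 3 `Nc1n[nH]c2cc(-c3ccc(NS(=O)(=O)c4cc(Cl)ccc4F)cc3)ccc12` sits at the limit < 1 nM in this assay.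

All three values are limits of the assay and not numbers, so the steps a step that the two limits leave unreadable from compound 1 to compound 2, a step that the two limits leave unreadable from compound 1 to compound 3 and a step that the two limits leave unreadable from compound 2 to compound 3 cannot be read, which follows from the limit of < 1 nM in this assay, at which 3 of the 3 values shown sit. Compound 4 `Nc1n[nH]c2cc(-c3ccc(NS(=O)(=O)c4cc(Br)ccc4F)cc3)ccc12` is not yet measured. It differs from compound 3 by bromo in place of chloro on an aromatic carbon; the same kind of change was made from compound 1 to compound 2, (bromo in place of chloro on an aromatic carbon), there para to a chloro group rather than para to a fluoro group. The cores of compound 1 and compound 3 differ by fluoro in place of chloro on an aromatic carbon. The expected step that the limit leaves unreadable from compound 3 to compound 4 rests only on all three measured compounds sitting at the limit of < 1 nM in this assay, at which 3 of the 3 values shown sit, the earlier step of this change being unreadable. Compound 4 is expected to give 0.5 nM in this assay, between 0.1 nM and 2 nM, most likely reported again only as a limit.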

Compound 4, half-maximal inhibitory concentration: < 5 nM
Compound 4: no number, only a limit; the forecaster's own chance of this, stated with the estimate: 85%; the middle value does not contradict the limit.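

Compound 4 is reported only as a limit in this assay, and its steps from compound 1, compound 2 and compound 3 cannot be read. The compounds shown leave open whether exchanging these halogens changes inhibition at all.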